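From Propylcarbonyl to Butyl: an Estimate for Compound 3

The source may report more compounds than this note shows. Statements on the series, on what has been measured and on what is new or still open speak of the compounds shown alone.

Compound 1 `CCC(=O)c1ccc2c(c1)sc(=O)n2CCCN1CCCCCC1`: 3.7 nM
Compound 2 `CCCC(=O)c1ccc2c(c1)sc(=O)n2CCCN1CCCCCC1`: 2.6 nM

In an assay on cell membranes for displacement of a labelled ligand from Sigma non-opioid intracellular receptor 1 (Rattus norvegicus) (a higher number here means a weaker inhibitor, a lower number a stronger inhibitor), compound 2 stands at one end of two numbers that are within the scatter of each other, since the step of a 1.4-fold lower number from compound 1 to compound 2 (0.15 log units; within the scatter) does not separate them. Compound 3 `CCCCc1ccc2c(c1)sc(=O)n2CCCN1CCCCCC1` carries butyl in place of propylcarbonyl on an aromatic carbon. Going by the values given here, the only measured step, the chain lengthening, bears on it weakly and was small. Among the compounds with values here, no measured pair shows the carbonyl leaving, so the direction is open. A small step is expected, a 1.5-fold higher number from compound 2 to compound 3 (0.19 log units; within the scatter). For compound 3 the estimate is 4 nM, with a range from 1 nM to 15 nM.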

Compound 3, inhibition constant: 2.2 nM
Compound 3: middle estimate off by 1.8-fold (0.26 log units), on the high side, and the stated range covers the measured number.
By their numbers in this assay, from the lowest: compounds 3, 2 and 1 (each within the scatter of the next).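

In this assay, the carbonyl on this aromatic carbon can give way to a plain butyl chain with no difference beyond the scatter (a 1.2-fold lower number from compound 2 to compound 3 (0.07 log units; within the scatter)), and the same holds against the shorter propanoyl (a 1.7-fold lower number from compound 1 to compound 3 (0.23 log units; within the scatter)). Binding at this position therefore does not depend on keeping the carbonyl, at least among these compounds. Nothing available explains why the two kinds of chain read alike. On these data alone, how an amine, a carboxylic acid or a longer chain on this aromatic carbon would read in this assay remains open.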